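The source may report more compounds than this note shows. Statements on the series, on what has been measured and on what is new or still open speak of the compounds shown alone.

Notes on the series. In an assay on CHO cells for displacement of a labelled ligand from adenosine receptor A3 (Homo sapiens), read by scintillation counting, with a stated time of 3 h (a higher number here means a weaker inhibitor, a lower number a stronger inhibitor), compound 1 `Cn1c(-c2cccc(Cl)c2)nc2c(NC3CCCC3)ncnc21` gives 514 nM. Compound 3 `CCCn1c(-c2ccccc2)nc2c(NC3CCCC3)ncnc21` gives 749 nM in this assay, a value that lies within the usual scatter of the number for compound 1, so the two cannot be placed in an order. Compound 2 `CCn1c(-c2ccccc2)nc2c(N)ncnc21` gives 5780 nM in this assay, a gap from compound 1 that is beyond the scatter. Going by the values given here, compound 1 therefore stands with the lowest number of the three measured so far, compound 3 close beside it and compound 2 far off. Among the compounds with values here, no two of these three differ in only one place, so no single step between measured compounds can be read from them.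

Compound 4 `Cn1c(-c2ccccc2Cl)nc2c(NC3CCCC3)ncnc21` has not been measured. It differs from compound 1 by 2-chlorophenyl in place of 3-chlorophenyl on an aromatic carbon. Within the data shown here, nothing among the measured compounds shows what moving the chlorine to another place on the phenyl group does, so the expectation rests on the structural change alone, with the value of compound 1 as the starting point. The step is estimated as a 2.1-fold higher number from compound 1 to compound 4 (0.33 log units; beyond the scatter), which would be a modest rise in the number, of about the size of the scatter or a little beyond it. For compound 4 in this assay the estimated value is 1100 nM, with a range from 350 nM to 3500 nM.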

Compound 4, inhibition constant: 720 nM
The estimate for compound 4 lay 1.5-fold (0.18 log units) above the measured number; measured number inside the range.
By their numbers in this assay, from the lowest: compounds 1, 4 and 3 (each within the scatter of the next); then compound 2.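

In this assay, going by these compounds alone, 2-chlorophenyl in place of 3-chlorophenyl comes to a 1.4-fold higher number from compound 1 to compound 4 (0.15 log units; within the scatter), the first step that can be read at a single place, and it leaves the two compounds without an order. For this pair, the chlorine can stand at either of these two places on the phenyl group, on the aromatic carbon between two ring nitrogen atoms, without a change that can be told from the usual scatter. No outside measurement bears on this result.

From the compounds shown here alone, what 4-chlorophenyl, or a phenyl group carrying methoxy or an amine instead of the chlorine, would do at this position remains open, as does any wider reading of the change beyond this one pair. Within the data shown here, the effect of having a chlorine at all is also open: compound 3 carries an unsubstituted phenyl group but differs from both chlorinated compounds in more than one place, so no step to it can be read.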